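A few compounds are considered here, and "the series" means these few. Any claim that something is new, unique, unknown or untested is made for them only; others in the source may bear on it.

Compound 1 `N#CC1=C(N)Oc2c(N)cc3nc4ccccc4nc3c2C12C(=O)N(Cc1cnnn1-c1cccc(C(F)(F)F)c1)c1ccccc12`: in a functional assay on HCT-116 cells (Homo sapiens) for antiproliferative activity, read by MTT assay, with a stated time of 48 h (a lower number here means a stronger inhibitor, a higher number a weaker inhibitor), compound 1 gives 18900 nM.
Compound 2 `Cc1ccc(-n2nncc2CN2C(=O)C3(C(C#N)=C(N)Oc4c(N)cc5nc6ccccc6nc5c43)c3ccccc32)cc1C`: in this assay compound 2 gives only the limit > 50000 nM.
Compound 3 `Cc1ccc(-n2nncc2CN2C(=O)C3(C(C#N)=C(N)Oc4c(N)cc5nc6ccccc6nc5c43)c3ccccc32)cc1Cl`: in this assay compound 3 gives only the limit > 50000 nM.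

Compound 3 thus stands at the limit of this assay rather than at a number (the limit of > 50000 nM in this assay, at which 2 of the 3 values shown sit). Compound 2 shares that limit, and the step that the two limits leave unreadable from compound 2 to compound 3 is therefore not readable. Compound 4 `COc1cc(-n2nncc2CN2C(=O)C3(C(C#N)=C(N)Oc4c(N)cc5nc6ccccc6nc5c43)c3ccccc32)c(OC)cc1Cl` differs from compound 3 by 4-chloro-2,5-dimethoxyphenyl in place of 3-chloro-4-methylphenyl on an aromatic nitrogen. The measured steps bearing on this position are an at least 2.6-fold higher number from compound 1 to compound 2 (0.42 log units; beyond the scatter) and an at least 2.6-fold higher number from compound 1 to compound 3 (0.42 log units; beyond the scatter), both exchanges of the aryl group on the same nitrogen, both toward weaker inhibition. Neither exchange closely resembles the present one, so no step beyond the scatter is expected in a number no higher from compound 3 to compound 4 (the limit leaves the size open). Compound 4 is therefore estimated at 50000 nM, between 20000 nM and 150000 nM, most likely again only a limit.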

Compound 4, half-maximal inhibitory concentration: > 50000 nM
Compound 4: no number, only a limit (the forecaster's own chance of this, stated with the estimate: 65%); the middle value sits exactly at the limit.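

In this assay, the 4-chloro-2,5-dimethoxyphenyl group, with its 2 hydrogen-bond acceptors, does not lift the series off the limit seen with the simpler aryl groups: the limit of > 50000 nM in this assay, at which 3 of the 4 values shown sit.

Going by these compounds alone, replacing 3-(trifluoromethyl)phenyl gives an at least 2.6-fold higher number from compound 1 to compound 4 (0.42 log units; beyond the scatter), the third such exchange in this direction, so the only number at this position still belongs to that group. The steps among the three compounds at the limit cannot be read.

From the compounds shown here alone, it remains open whether a carboxylic acid or a dimethylamino group on the aryl ring would give a number in this assay. Also open, going by these compounds, is whether anything on this nitrogen would give a lower number than the trifluoromethyl-bearing group.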